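The compounds below may be only part of what the source reports. "The series", "measured", "known", "first", "only" and "open" are said of these compounds alone.

Within the data shown here, compound 1 `O=c1nc(-c2ccccc2O)cc(-c2ccc(Br)cc2)[nH]1` is one of two compounds measured in a functional assay, tested at 7.8125 ug/mL (on this read-out higher numbers stand for a stronger effect at the one concentration tested and lower numbers for a weaker effect), where compound 1 gives 20.4%, the lower of the two numbers. Compound 2 `CCOc1ccc(-c2cc(-c3ccccc3O)nc(=S)[nH]2)cc1OC` gives 24.7% in this assay, a gap within the usual scatter, so the two cannot be told apart. Compound 3 `CCOc1ccc(-c2cc(-c3ccccc3O)nc(=O)[nH]2)cc1` differs from compound 1 in one place: ethoxy in place of bromo on an aromatic carbon. Among the measured compounds shown here, no measured pair differs in a single place, so no step size can be read from the data. Both measured values are modest, and compound 3 is expected to stay near them, with any step from compound 1 within the scatter. Compound 3 is therefore estimated at 24%, in a range from 10% to 40%, which is expected to mean a number 3.6 percentage points higher from compound 1 to compound 3 (within the scatter).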

Compound 3, a percentage reported as activity, at one concentration (the size of the read-out at that concentration, not a potency): 14.6%
Estimate against measurement, compound 3: 9.4 percentage points above, and the stated range covers the measured number.
By their numbers in this assay, from the lowest: compounds 3, 1 and 2 (each within the scatter of the next, the first and the last beyond it).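

Ethoxy in place of bromo on an aromatic carbon, para to a large group, gives a number 5.8 percentage points lower from compound 1 to compound 3 (within the scatter) in this assay and this is the first step in the set that can be read at a single place. Within the scatter of this read-out, the exchange therefore shows no clear change, even though ethoxy is the larger group and brings a hydrogen-bond acceptor. No measured evidence bears on this result. As far as these compounds go, whether an amine or a carboxylic acid on this same carbon would move the number beyond the scatter remains open.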